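This account rests on a few compounds, and the source may have more. Where it says the series, first, only, none or still open, it means among the compounds named here.

Measured so far:
- Compound 1 `O=C(/C=C/c1cccnc1)NCCCCc1ccc(S(=O)(=O)Nc2ccccc2)cc1`: 47.9 nM
- Compound 2 `O=C(/C=C/c1cccnc1)NCCCCCc1cccc(S(=O)(=O)Nc2ccccc2)c1`: 140 nM
- Compound 3 `Cc1ccc(NS(=O)(=O)c2cccc(CCCCCCNC(=O)/C=C/c3cccnc3)c2)cc1`: 34.4 nM

All three values come from a functional assay on DU-145 cells (Homo sapiens) for inhibition, read by CCK-8 assay, with a stated time of 72 h; on this read-out lower numbers stand for stronger inhibition and higher numbers for weaker inhibition. Compound 3 at 34.4 nM sits at the low end of this small set, within the scatter of compound 1 at 47.9 nM. Compound 2 at 140 nM has a higher number than compound 3, beyond the scatter.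

Next in this assay is compound 4 `O=C(/C=C/c1cccnc1)NCCCCCCc1cccc(S(=O)(=O)Nc2ccc(F)cc2)c1`, with this change from compound 3: fluoro in place of methyl on an aromatic carbon. This is fluoro in place of methyl on an aromatic carbon, 4-methylphenyl to 4-fluorophenyl. For the measured compounds named here, no measured pair isolates this change, so no shift beyond the scatter is expected. The estimated step, a 1.1-fold lower number from compound 3 to compound 4 (0.06 log units; within the scatter), stays within the scatter. Compound 4 is expected at 30 nM, with an estimated range of 12 nM to 80 nM.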

Compound 4, half-maximal inhibitory concentration: 10.6 nM
Estimate against measurement, compound 4: 2.8-fold (0.45 log units) above, outside the stated range (below it).
By their numbers in this assay, from the lowest: compound 4; then compounds 3 and 1 (each within the scatter of the next); then compound 2.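

In this assay, for the compounds shown here, 4-methylphenyl to 4-fluorophenyl gives a 3.2-fold lower number from compound 3 to compound 4 (0.51 log units; beyond the scatter), the first single-place comparison. It shows that the number responds to the group on this aromatic carbon, para to a large group, and that this one-atom exchange is enough to move it beyond the scatter. Nothing at hand explains the shift.

Going by these compounds, whether chloro or methoxy on the same carbon would give a similar step remains open. Also open, on these data alone, is whether the step carries over to the cores of compound 1 and compound 2.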